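Dimethylamino in Place of Nitro: an Expected Potency

A few compounds are considered here, and "the series" means these few. Any claim that something is new, unique, unknown or untested is made for them only; others in the source may bear on it.

Three compounds have been measured in an assay on HEK293 cells for antagonist activity at P2X purinoceptor 7 (Homo sapiens), read by fluorescence, with a stated time of 2 h; on this read-out higher numbers stand for weaker inhibition and lower numbers for stronger inhibition:

compound 1, `O=C(c1ccc(Cl)c(C(F)(F)F)c1)N1CCC(c2nc3cc(OS(=O)(=O)c4cccc5cnccc45)ccc3[nH]2)CC1`, gives 31 nM
compound 2, `CS(=O)(=O)c1ccc(C(=O)N2CCC(c3nc4cc(OS(=O)(=O)c5cccc6cnccc56)ccc4[nH]3)CC2)cc1`, gives 7 nM
compound 3, `O=C(c1ccc([N+](=O)[O-])cc1)N1CCC(c2nc3cc(OS(=O)(=O)c4cccc5cnccc45)ccc3[nH]2)CC1`, gives 13 nM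

Compound 3 holds the second highest of the three numbers. Its nearest neighbour is compound 2, and the step of a 1.9-fold higher number from compound 2 to compound 3 (0.27 log units; within the scatter) lies within the scatter; its furthest is compound 1, separated by the step of a 2.4-fold lower number from compound 1 to compound 3 (0.38 log units; beyond the scatter), which is beyond the scatter but modest.

Compound 4, `CN(C)c1ccc(C(=O)N2CCC(c3nc4cc(OS(=O)(=O)c5cccc6cnccc56)ccc4[nH]3)CC2)cc1`, differs from compound 3 by dimethylamino in place of nitro on an aromatic carbon. For the measured compounds named here, the only measured step at that same aromatic carbon, from methylsulfonyl to nitro, is a 1.9-fold higher number from compound 2 to compound 3 (0.27 log units; within the scatter), within the scatter. The steps that exchange the whole aryl group on the carbonyl carbon, a 4.4-fold lower number from compound 1 to compound 2 (0.65 log units; beyond the scatter) and a 2.4-fold lower number from compound 1 to compound 3 (0.38 log units; beyond the scatter), were both modest. On that basis a swap of the group para to the large group is expected to move the number in this assay by little, with at most a modest rise; compound 4 is therefore estimated at 20 nM, between 7 nM and 60 nM, a step of a 1.5-fold higher number from compound 3 to compound 4 (0.19 log units; within the scatter).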

Compound 4, half-maximal inhibitory concentration: 41 nM
The estimate for compound 4 lay 2.1-fold (0.31 log units) below the measured number, within the range that was stated.
By their numbers in this assay, from the lowest: compounds 2 and 3 (each within the scatter of the next); then compounds 1 and 4 (each within the scatter of the next).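

In this assay, for the compounds shown here, the earlier compounds offered only the exchange of methylsulfonyl and nitro on this aromatic carbon, para to a large group, and that exchange stayed within the scatter. Dimethylamino gives the first steps at this carbon beyond the scatter, as the steps of a 3.2-fold higher number from compound 3 to compound 4 (0.50 log units; beyond the scatter) and a 5.9-fold higher number from compound 2 to compound 4 (0.77 log units; beyond the scatter) are both modest but clear of it, while the step of a 1.3-fold higher number from compound 1 to compound 4 (0.12 log units; within the scatter) lies within the scatter, so the advantage over compound 1 seen with methylsulfonyl and nitro is not seen with dimethylamino. No measurement shown here accounts for these steps.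

The compounds shown leave open whether a primary amine or a methylamino group at this carbon would read like dimethylamino, and whether a carboxylic acid or a nitrile would read like nitro and methylsulfonyl. They also leave open how a longer chain on that nitrogen would read.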